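Side-chain changes on the shared core: compound 3 to compound 4

A few compounds are considered here, and "the series" means these few. Any claim that something is new, unique, unknown or untested is made for them only; others in the source may bear on it.

- compound 1 `O=C1c2c[n+]([O-])c3ccccc3c2C(=O)c2c1c1ccccc1n2Cc1cn([C@@H]2C[C@H](O)[C@@H](CO)O2)nn1`: 120 nM
- compound 2 `O=C1c2c[n+]([O-])c3ccccc3c2C(=O)c2c1c1ccccc1n2Cc1cn(C[C@H](O)CO)nn1`: 1030 nM
- compound 3 `CC1(C)O[C@@H](CO)[C@H](Cn2cc(Cn3c4c(c5ccccc53)C(=O)c3c[n+]([O-])c5ccccc5c3C4=O)nn2)O1`: 370 nM

In a functional assay on A549 cells (Homo sapiens) for cytotoxicity, read by MTT assay, with a stated time of 72 h (on this read-out higher numbers stand for weaker inhibition and lower numbers for stronger inhibition), compound 3 holds the middle place of the three numbers, with compound 1 lower and compound 2 higher. The next structure is compound 4 `CC1(C)OC[C@@H](Cn2cc(Cn3c4c(c5ccccc53)C(=O)c3c[n+]([O-])c5ccccc5c3C4=O)nn2)O1`. The change is 2,2-dimethyl-1,3-dioxolan-4-yl in place of 5-(hydroxymethyl)-2,2-dimethyl-1,3-dioxolan-4-yl on a saturated chain carbon bound to an aromatic nitrogen.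

Within the data shown here, no measured step isolates this change. The nearest evidence is a 2.8-fold lower number from compound 2 to compound 3 (0.44 log units; beyond the scatter), which involves the same place, alongside a 3.1-fold higher number from compound 1 to compound 3 (0.49 log units; beyond the scatter) and an 8.6-fold higher number from compound 1 to compound 2 (0.93 log units; beyond the scatter). All three are modest, so a modest step at most is expected in this assay, and the data fix no firm direction. The estimated step is a 1.2-fold lower number from compound 3 to compound 4 (0.06 log units; within the scatter). For compound 4 the expected value is 320 nM, with an estimated range of 120 nM to 850 nM.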

Compound 4, half-maximal inhibitory concentration: 4700 nM
Beside the measured number, compound 4's estimate is 15-fold (1.17 log units) below it; measured number outside the range, above it.
By their numbers in this assay, from the lowest: compound 1; then compound 3; then compound 2; then compound 4.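

In this assay, among these compounds, loss of the hydroxymethyl from the dioxolane gives a 13-fold higher number from compound 3 to compound 4 (1.10 log units; beyond the scatter) and is the first large step at this position on a saturated chain carbon bound to an aromatic nitrogen, so the substituent on this ring matters more than the modest steps among compounds 1 to 3 showed. Compound 4 also falls behind the open-chain 1,2-dihydroxyethyl compound, with a 4.6-fold higher number from compound 2 to compound 4 (0.66 log units; beyond the scatter) as the step, and the gap to the 4-hydroxy-5-(hydroxymethyl)oxolan-2-yl compound widens to a 39-fold higher number from compound 1 to compound 4 (1.59 log units; beyond the scatter) as the step, leaving compound 4 the weakest of the four on this read-out. Nothing on hand bears on why removing this group costs so much.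

On these data alone, whether the hydroxyl itself or the extra carbon carries the effect stays open. A methoxymethyl or an aminomethyl group in place of the hydroxymethyl would separate the two.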